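Benzamide and acrylamide thioethers: growth inhibition working notes

The compounds below may be only part of what the source reports. "The series", "measured", "known", "first", "only" and "open" are said of these compounds alone.

Measured compounds:
compound 1 `Cc1cc(C)cc(SCc2ccc(/C=C/C(=O)Nc3ccccc3N)cc2)c1` gives 8.61%
compound 2 `Nc1ccccc1NC(=O)/C=C/c1ccc(CSc2ccc(Cl)cc2)cc1` gives 15.2%
compound 3 `Nc1ccccc1NC(=O)c1ccc(CSc2ccc(Cl)cc2)cc1` gives 2.93%

The read-out for all three is a functional assay on SMMC-7721 cells (Homo sapiens) for inhibition, read by CCK-8 assay, with a stated time of 72 h, tested at 2 uM; a higher number here means more inhibition of growth at the concentration tested, a lower number less inhibition of growth. Compound 3 has the lowest of the three numbers; compound 1 lies within the scatter of it, while compound 2 stands beyond the scatter above it. The difference between the core of compound 2 and the core of compound 3 is not broken down here.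

One change is seen within the acrylamide pair: 3,5-dimethylphenyl in place of 4-chlorophenyl on a sulfur. It gave a number 6.6 percentage points lower from compound 2 to compound 1 (within the scatter), a step within the scatter.

Compound 4 `Cc1cc(C)cc(SCc2ccc(C(=O)Nc3ccccc3N)cc2)c1` has not been measured. It carries the same change against compound 3: 3,5-dimethylphenyl in place of 4-chlorophenyl on a sulfur. The surroundings of the place are the same word for word, so this is the same change on a different core.

The step from compound 3 to compound 4 is expected to be a number 0.1 percentage points higher from compound 3 to compound 4 (within the scatter), a small one, because the same change gave a number 6.6 percentage points lower from compound 2 to compound 1 (within the scatter). Compound 4 is accordingly expected to give about 3% in this assay, with a likely range from -8% to 14%. Among the compounds with values here, only one earlier instance of the change exists, so the expectation rests on a single step.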

Compound 4, percent growth inhibition at one concentration: 29.1%
For compound 4 the middle estimate is 26.1 percentage points below the measured one; measured number outside the range, above it.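

In this assay, replacing 4-chlorophenyl with 3,5-dimethylphenyl on a sulfur on the core of compound 3 gave a number 26.2 percentage points higher from compound 3 to compound 4 (beyond the scatter), and this result does not match the step seen on the core of compound 2. Within this series, the same change therefore cannot be carried from one core to the other with its size and direction intact: the same change on two cores in this assay, a number 6.6 percentage points lower (within the scatter) from compound 2 to compound 1 and a number 26.2 percentage points higher (beyond the scatter) from compound 3 to compound 4, 32.8 percentage points apart, beyond the scatter of two such steps

This rests on a single pair for each core, which shows that the earlier step was a poor guide to the new one, but it does not show why the two steps differ or whether any other change would behave in the same way.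

The compounds shown leave open whether an unsubstituted phenyl or a cyclohexyl on the sulfur would give different steps on the two cores. Also open, from the compounds shown here alone, is how the result would shift with an oxygen in place of the sulfur, or with a longer chain between the sulfur and the core.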